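A few compounds are considered here, and "the series" means these few. Any claim that something is new, unique, unknown or untested is made for them only; others in the source may bear on it.

Measured so far in a functional assay on cells (Cancer cell lines, Homo sapiens) for cytotoxicity, read by sulforhodamine B assay, with a stated time of 48 h; a higher number here means a weaker inhibitor of growth, a lower number a stronger inhibitor of growth:
- compound 1 `O=C1N=C(N2N=C(c3ccccc3)CC2c2ccccc2O)S/C1=C1/C(=O)Nc2ccccc21`: 1990 nM
- compound 2 `O=C1N=C(N2N=C(c3ccccc3)CC2c2ccccc2O)S/C1=C1/C(=O)Nc2ccc(Br)cc21`: 210 nM

Compound 1 stands at the highest of the two numbers in this assay; the nearest is compound 2, with a 9.5-fold lower number from compound 1 to compound 2 (0.98 log units; beyond the scatter). That step is a change on the aromatic carbon of the fused bicyclic part of the shared core, away from the five-membered ring.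

Compound 3 `O=C1N=C(N2N=C(c3ccccc3)CC2c2ccc(Cl)cc2)S/C1=C1/C(=O)Nc2ccccc21` is not yet measured. It differs from compound 1 by 4-chlorophenyl in place of 2-hydroxyphenyl on a saturated ring carbon. Among the compounds with values here, the only measured step sits at a different place of the core and does not bear directly on this change. With nothing that speaks to an exchange at the saturated ring carbon, the expectation for compound 3 rests on compound 1 alone, and the step is expected to stay small, within or near the scatter, in no firm direction: a 1.3-fold lower number from compound 1 to compound 3 (0.12 log units; within the scatter). Compound 3 is estimated at 1500 nM in this assay, with a range from 400 nM to 6000 nM.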

Compound 3, concentration for 50% growth inhibition: 190 nM
Compound 3: the middle estimate sits 7.9-fold (0.90 log units) above what was measured; measured number outside the range, below it.
By their numbers in this assay, from the lowest: compounds 3 and 2 (each within the scatter of the next); then compound 1.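

In this assay the saturated ring carbon next to the ring nitrogen proves a responsive position: 4-chlorophenyl in place of 2-hydroxyphenyl gives a 10-fold lower number from compound 1 to compound 3 (1.02 log units; beyond the scatter) in a single exchange. Both groups have 7 heavy atoms, but the step combines loss of the hydroxyl, gain of chlorine and a different substitution place on the phenyl ring, so it cannot be divided among these three. No data on hand explain the step.

The compounds shown leave open whether plain phenyl, 2-chlorophenyl or 4-hydroxyphenyl at this carbon would separate these contributions, and how a 4-aminophenyl group would fare there. They also leave open whether 4-chlorophenyl at this carbon and bromo on the aromatic carbon would add up within one compound.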